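The compounds below may be only part of what the source reports. "The series", "measured", "known", "first", "only" and "open" are said of these compounds alone.

In a functional assay on P388 cells (Mus musculus) for cytotoxicity, read by MTT assay, with a stated time of 72 h (on this read-out lower numbers stand for stronger inhibition and higher numbers for weaker inhibition), the three measured compounds give these numbers:

Compound 1, `OCC#CCSc1cnc2ccccc2c1Cl`: 2.4 ug/mL
Compound 2, `OCC#CCSc1cnc2ccccc2c1[Se]CC#CCBr`: 1.6 ug/mL
Compound 3, `C[Se]c1c(SCC#CCO)cnc2ccccc12`: 19.8 ug/mL

Compound 3 stands at the highest number of the three, which on this read-out means the weakest inhibition, and both of its steps to the others, an 8.3-fold higher number from compound 1 to compound 3 (0.92 log units; beyond the scatter) and a 12-fold higher number from compound 2 to compound 3 (1.09 log units; beyond the scatter), lie beyond the scatter. Compound 4, `COc1c(SCC#CCO)cnc2ccccc12`, differs from compound 3 in one place: a group of 2 heavy atoms (1 carbon, 1 oxygen; no ring) in place of a group of 2 heavy atoms (1 carbon, 1 selenium; no ring), on an aromatic carbon. Among the measured compounds shown here, no measured step exchanges one small group for another at this carbon, so the expectation rests on what the neighbouring steps show. The step of an 8.3-fold higher number from compound 1 to compound 3 (0.92 log units; beyond the scatter) shows that putting a small selenium-bearing group on this carbon in place of chlorine raised the number by a modest margin, whereas a 1.5-fold lower number from compound 1 to compound 2 (0.18 log units; within the scatter) shows that a much larger group at the same carbon changed nothing beyond the scatter. What sits on this carbon can therefore matter a good deal or not at all. Since compound 3 already carries a small group and compound 4 only swaps it for another small one, compound 4 is expected to move down somewhat, a 2.0-fold lower number from compound 3 to compound 4 (0.30 log units; within the scatter), without reaching compound 1. Compound 4 is estimated at 10 ug/mL, with a range from 3 ug/mL to 30 ug/mL.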

Compound 4, concentration for 50% inhibition: 23.2 ug/mL
The estimate for compound 4 lay 2.3-fold (0.37 log units) below the measured number, and the stated range covers the measured number.
By their numbers in this assay, from the lowest: compounds 2 and 1 (each within the scatter of the next); then compounds 3 and 4 (each within the scatter of the next).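

In this assay the exchange of selenium for oxygen in the small group on this aromatic carbon gives a 1.2-fold higher number from compound 3 to compound 4 (0.07 log units; within the scatter) and so leaves the two groups indistinguishable here. Methoxy stands apart from the other two groups just as the small selenium-bearing group does: putting it in place of chloro gives a 9.7-fold higher number from compound 1 to compound 4 (0.99 log units; beyond the scatter) and putting it in place of the group of 6 heavy atoms gives a 15-fold higher number from compound 2 to compound 4 (1.16 log units; beyond the scatter) in the same direction. The high number at this carbon is therefore not tied to selenium, since it appears with oxygen too, and it does not follow size in any simple way, for compound 1 with chloro and compound 2 with its much larger group go against such a reading by both giving low numbers.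

On these data alone, whether an amine, a methylthio group or a longer chain such as butoxy on this carbon would keep the number high or bring it down stays open, as does whether the low numbers depend on chlorine and on the bromine-bearing chain themselves. Nothing available gives a reason for any of these steps.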